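The compounds below may be only part of what the source reports. "The series", "measured", "known", "first", "only" and "open" are said of these compounds alone.

Compound 1 `Cc1ccc(OCc2cn(-c3ccc(S(=O)(=O)N4CCc5ccccc5C4)cc3)nn2)cc1` and compound 2 `COc1cc2c(cc1OC)CN(S(=O)(=O)c1ccc(-n3cc(COc4ccc([N+](=O)[O-])cc4)nn3)cc1)CC2` share the same aryl-triazole sulfonamide framework and were both examined in an ADME assay on Vero cells (Chlorocebus sabaeus) for cytotoxicity, with a stated time of 4 days; on this read-out higher numbers stand for weaker inhibition and lower numbers for stronger inhibition. In this assay compound 1 gives > 50 ug/mL, which is a limit of the assay and not a number. Compound 2 likewise reaches only a limit in this assay, where compound 2 gives > 50 ug/mL. This is summed up by the limit of > 50 ug/mL in this assay, at which 2 of the 2 values shown sit: neither compound shows measurable toxicity toward the cells within the tested range, and no order between compound 1 and compound 2 can be drawn from these two limits.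

Compound 3 `COc1cc2c(cc1OC)CN(S(=O)(=O)c1ccc(-n3cc(COc4ccc(C)cc4)nn3)cc1)CC2` has not yet been measured in this assay. It keeps the dimethoxy core of compound 2 and differs from it by methyl in place of nitro on an aromatic carbon, giving the 4-methylphenoxymethyl group that compound 1 also carries. Since no difference beyond the scatter has been seen among the measured compounds, the step that the limit leaves unreadable from compound 2 to compound 3 is expected to amount to nothing beyond the scatter. Compound 3 is therefore expected to give about 70 ug/mL, within 40 ug/mL to 160 ug/mL, most probably again reported only as a limit.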

Compound 3, half-maximal inhibitory concentration: > 50 ug/mL
Compound 3: a limit, no number (the forecaster's own chance of this, stated with the estimate: 85%); the middle value is on the limit's open side.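

In this assay compound 3 gives > 50 ug/mL as a limit of the assay and not a number, so the change of methyl in place of nitro between compound 2 and compound 3 cannot be read: the limit of > 50 ug/mL in this assay, at which 3 of the 3 values shown sit. The compounds shown leave open how compound 1, compound 2 and compound 3 would rank in this assay and at what concentration any of them would harm the cells.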